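The source may report more compounds than this note shows. Statements on the series, on what has been measured and on what is new or still open speak of the compounds shown alone.

Measured in a physicochemical assay for solubility, at pH 7; on this read-out higher numbers stand for higher solubility and lower numbers for lower solubility:
compound 1 `CN1CCC(C(=O)N2Cc3c(NC(=O)C4CC4)n[nH]c3C2(C)C)CC1`: > 225000 nM (a limit)
compound 2 `CN1CCC(C(=O)N2Cc3c(NC(=O)NCc4ccccc4)n[nH]c3C2(C)C)CC1`: > 225000 nM (a limit)
compound 3 `CN1CCC(C(=O)N2Cc3c(NC(=O)c4ccncc4)n[nH]c3C2(C)C)CC1`: > 225000 nM (a limit)

Within the data shown here, every value so far is a limit: the limit of > 225000 nM in this assay, at which 3 of the 3 values shown sit. Compound 3 therefore has no number of its own, and its place in the series cannot be ranked against the other two.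

Compound 4 `CN1CCC(C(=O)N2Cc3c(NC(=O)c4cccc(F)c4)n[nH]c3C2(C)C)CC1` differs from compound 3 by 3-fluorophenyl in place of pyridin-4-yl on a carbonyl carbon.

The measured steps at this same place are a step that the two limits leave unreadable from compound 1 to compound 3 and a step that the two limits leave unreadable from compound 2 to compound 3. Neither has a readable size, so they give only weak guidance.

Compound 2 carries benzylamino on that carbonyl carbon and shows the limit > 225000 nM. On that basis, no step beyond the scatter is expected in this assay, though any shift would more likely be downward.

The estimated step is an at least 1.1-fold lower number from compound 3 to compound 4 (0.05 log units; that floor lies within the scatter).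

Compound 4 is expected at about 200000 nM, with an estimated range of 90000 nM to 300000 nM.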

Compound 4, solubility: > 225000 nM
Compound 4: a limit, no number (the forecaster's own chance of this, stated with the estimate: 60%); at least 1.1-fold (0.05 log units) between middle value and limit.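

No step from compound 1, compound 2 or compound 3 to compound 4 can be read in this assay: the limit of > 225000 nM in this assay, at which 4 of the 4 values shown sit.

The compounds shown leave open how these four rank in this assay, and whether 3-fluorophenyl in place of pyridin-4-yl on a carbonyl carbon changes the read-out at all.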